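From pyridin-2-yl to pyridin-4-yl on a shared core

The compounds below may be only part of what the source reports. "The series", "measured", "known", "first", "only" and "open" are said of these compounds alone.

Of the compounds shown here, three have numbers so far in a functional assay on prostate cells (Homo sapiens) for antiproliferative activity; a higher number here means a weaker inhibitor of growth, a lower number a stronger inhibitor of growth: compound 1 (`Cc1cn2c(/C=N/NC(=N)N)c(-c3cccnc3)nc2s1`), compound 2 (`N=C(N)N/N=C/c1c(-c2cc([N+](=O)[O-])c(Cl)cc2Cl)nc2sc(Cl)cn12`) and compound 3 (`N=C(N)N/N=C/c1c(-c2ccccn2)nc2sc(Cl)cn12`). Compound 1 gives 24500 nM and compound 2 gives 93300 nM. Compound 3 gives 17800 nM, within the scatter of the number for compound 1. Together these two sit at the low end of the three numbers, while compound 2 stands higher than compound 3 by a gap beyond the scatter.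

The next compound, compound 4 (`N=C(N)N/N=C/c1c(-c2ccncc2)nc2sc(Cl)cn12`), keeps the core of compound 3 and carries pyridin-4-yl in place of pyridin-2-yl on an aromatic carbon. Among the compounds with values here, no two measured compounds differ in one place only, so the data hold no direct measure of such a swap. The nearest guide differs from compound 3 in more than one place and is compound 1, which gives 24500 nM, still within the scatter. Against this, compound 2 at 93300 nM shows that the number can move, so the range is kept wide. No step beyond the scatter is expected, in either direction. The expected size of the change is a 1.2-fold higher number from compound 3 to compound 4 (0.07 log units; within the scatter). Compound 4 is estimated at 21000 nM, with an expected range of 9500 nM to 47000 nM.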

Compound 4, concentration for total growth inhibition: 33100 nM
Beside the measured number, compound 4's estimate is 1.6-fold (0.20 log units) below it; the range from low to high includes it.
By their numbers in this assay, from the lowest: compounds 3, 1 and 4 (each within the scatter of the next); then compound 2.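

Within the data shown here, this is the first pair in this assay that differs in one place only, so the position on the aromatic carbon next to the ring nitrogen now has a direct reading: a 1.9-fold higher number from compound 3 to compound 4 (0.27 log units; within the scatter). The step stays within the scatter, so on the core of compound 3 this assay does not separate pyridin-2-yl from pyridin-4-yl, two groups with the same atoms and the same counts of hydrogen-bond donors and acceptors, joined differently. Nothing available bears on why the step has this size, and the pair alone offers no explanation for it.

The compounds shown leave open whether a group of another kind at this place, such as an amine, a carboxylic acid or a longer alkyl chain, would give a step beyond the scatter on this core. Also open, from the compounds shown here alone, is how pyridin-3-yl, which compound 1 carries on its own core, would read on the core of compound 3, since only that third placement of the ring nitrogen would complete the set of pyridines there.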